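A few compounds are considered here, and "the series" means these few. Any claim that something is new, unique, unknown or untested is made for them only; others in the source may bear on it.

Measured so far in an ADME assay on L6 cells (Rattus norvegicus) for cytotoxicity, read by resazurin assay, with a stated time of 70 h; on this read-out higher numbers stand for weaker inhibition and lower numbers for stronger inhibition:

Compound 1 `N=C(N)c1ccc2cc(-c3cccc(OCCCOc4ccccc4)c3)oc2c1`: 19800 nM
Compound 2 `CC(C)NC(=N)c1ccc2cc(-c3cccc(OCCCOc4ccccc4)c3)oc2c1`: 82300 nM
Compound 3 `N=C(N)c1ccc2cc(-c3ccc(OCCCOc4ccccc4)cc3)oc2c1`: 8600 nM

Compound 1 and compound 3 share the same atoms joined differently; the difference between the two cores is not broken down here. Compound 3 gives the lowest number of the three, and its gap to compound 1 and to compound 2 lies beyond the scatter.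

One change is seen once and is now to be repeated. From compound 1 to compound 2 the change is isopropyl in place of hydrogen on an amine nitrogen, and in this assay it made a 4.2-fold higher number from compound 1 to compound 2 (0.62 log units; beyond the scatter). Compound 4 `CC(C)NC(=N)c1ccc2cc(-c3ccc(OCCCOc4ccccc4)cc3)oc2c1` arises from compound 3 by isopropyl in place of hydrogen on an amine nitrogen, a change of the same kind at the same place.

The step from compound 3 to compound 4 in this assay is expected to be about a 4.1-fold higher number from compound 3 to compound 4 (0.61 log units; beyond the scatter), resting on the step of a 4.2-fold higher number from compound 1 to compound 2 (0.62 log units; beyond the scatter). Compound 4 is therefore estimated at 35000 nM, likely between 15000 nM and 80000 nM.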

Compound 4, half-maximal inhibitory concentration: 49900 nM
Compound 4: the middle estimate sits 1.4-fold (0.15 log units) below what was measured; low and high end bracket the measured number.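

In this assay, isopropyl in place of hydrogen on an amine nitrogen gave a 5.8-fold higher number from compound 3 to compound 4 (0.76 log units; beyond the scatter), and this step matches the earlier one on the other core: the same change on two cores in this assay, a 4.2-fold higher number (0.62 log units; beyond the scatter) from compound 1 to compound 2 and a 5.8-fold higher number (0.76 log units; beyond the scatter) from compound 3 to compound 4, 1.4-fold (0.14 log units) apart, within the scatter of two such steps

On these two cores, then, the change carried over in both direction and size. For the compounds shown here, this rests on only two pairs and a single group, however, so it shows nothing about other cores or other assays, and it does not explain why the number rises.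

The compounds shown leave open whether a methyl or a cyclopentyl group on the same nitrogen would give a step of similar size. They also leave open whether the step would hold on a core with a longer ether chain.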